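From methylated amide to amine on the long chain

A few compounds are considered here, and "the series" means these few. Any claim that something is new, unique, unknown or untested is made for them only; others in the source may bear on it.

For the measured compounds named here, in a functional assay on HT-29 cells (Homo sapiens) for inhibition, read by sulforhodamine B assay, with a stated time of 48 h (on this read-out lower numbers stand for stronger inhibition of growth and higher numbers for weaker inhibition of growth), compound 2 (`CCCCCCCCCCCC[C@@H](O)[C@H]1CC[C@H]([C@H](O)CCCCCCCCCCN(C)C(=O)c2ccnn2C)O1`) gives 8130 nM as the lower of the two numbers so far, while compound 1 (`CCCCCCCCCCCC[C@@H](O)[C@H]1CC[C@H]([C@H](O)CCCCCCCCCCNC(=O)c2ccnn2C)O1`) gives 100000 nM on the same scale. Compound 3 (`CCCCCCCCCCCC[C@@H](O)[C@H]1CC[C@H]([C@H](O)CCCCCCCCCCNCc2ccnn2C)O1`) differs from compound 2 by this change (((1-methyl-1H-pyrazol-5-yl)methyl)amino in place of methyl((1-methyl-1H-pyrazol-5-yl)carbonyl)amino on a saturated chain carbon, ten or more bonds along the chain from an oxygen on a saturated carbon and a saturated ring carbon). Going by the values given here, the only measured step, a 12-fold lower number from compound 1 to compound 2 (1.09 log units; beyond the scatter) with methyl in place of hydrogen on an amide-type nitrogen, is large. Among the compounds with values here, compound 3 again carries a hydrogen on that nitrogen, but no measured step covers loss of the carbonyl. A modest rise is therefore expected, namely a 2.5-fold higher number from compound 2 to compound 3 (0.39 log units; beyond the scatter) in this assay as estimated here. The estimate for compound 3 is 20000 nM with an expected range from 4000 nM to 90000 nM in repeated measurements.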

Compound 3, concentration for 50% growth inhibition: 3020 nM
Compound 3: middle estimate off by 6.6-fold (0.82 log units), on the high side; the measured number lies below the stated range.
By their numbers in this assay, from the lowest: compound 3; then compound 2; then compound 1.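

In this assay the loss of the carbonyl lowers the number, with a 2.7-fold lower number from compound 2 to compound 3 (0.43 log units; beyond the scatter) even though the nitrogen carries a hydrogen again. For the compounds shown here, with that hydrogen kept on both sides, (1-methyl-1H-pyrazol-5-yl)methyl in place of (1-methyl-1H-pyrazol-5-yl)carbonyl gives a 33-fold lower number from compound 1 to compound 3 (1.52 log units; beyond the scatter) and is the largest step so far. Nothing measured here accounts for either step. The compounds shown leave open whether a methyl on the amine nitrogen of compound 3 would lower the number further. They also leave open how a shorter chain would read at this position.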